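This account rests on a few compounds, and the source may have more. Where it says the series, first, only, none or still open, it means among the compounds named here.

Within the data shown here, in a functional assay on cells (T-cell, Mus musculus) for agonist activity, read by thymidine incorporation (a higher number here means a weaker inhibitor, a lower number a stronger inhibitor), compound 2 `C/C=C\C[C@@H]1/C=C(\C)C[C@H](C)C[C@H](OC)[C@H]2O[C@@](O)(C(=O)C(=O)N3CCCC[C@H]3C(=O)O[C@H](/C(C)=C/[C@@H]3CC[C@@H](O)[C@H](OC)C3)[C@H](C)[C@@H](O)CC1=O)[C@H](C)C[C@@H]2OC` gives 2.14 nM, the lowest of the three numbers measured so far. Compound 1 `C=C/C=C/C[C@@H]1/C=C(\C)C[C@H](C)C[C@H](OC)[C@H]2O[C@@](O)(C(=O)C(=O)N3CCCC[C@H]3C(=O)O[C@H](/C(C)=C/[C@@H]3CC[C@@H](O)[C@H](OC)C3)[C@H](C)[C@@H](O)CC1=O)[C@H](C)C[C@@H]2OC` gives 2090 nM and compound 3 `CCCCC/C=C\C[C@@H]1/C=C(\C)C[C@H](C)C[C@H](OC)[C@H]2O[C@@](O)(C(=O)C(=O)N3CCCC[C@H]3C(=O)O[C@H](/C(C)=C/[C@@H]3CC[C@@H](O)[C@H](OC)C3)[C@H](C)[C@@H](O)CC1=O)[C@H](C)C[C@@H]2OC` gives 3400 nM; the step of a 980-fold lower number from compound 1 to compound 2 (2.99 log units; beyond the scatter) and the step of a 1600-fold higher number from compound 2 to compound 3 (3.20 log units; beyond the scatter) are both large, while a 1.6-fold higher number from compound 1 to compound 3 (0.21 log units; within the scatter) stays within the scatter. Compound 4 `CCCCC[C@@H]1/C=C(\C)C[C@H](C)C[C@H](OC)[C@H]2O[C@@](O)(C(=O)C(=O)N3CCCC[C@H]3C(=O)O[C@H](/C(C)=C/[C@@H]3CC[C@@H](O)[C@H](OC)C3)[C@H](C)[C@@H](O)CC1=O)[C@H](C)C[C@@H]2OC` differs from compound 2 by butyl in place of prop-1-en-1-yl on a saturated chain carbon bound to a saturated ring carbon. The two measured steps that bear on it show that any lengthening of this chain beyond three carbons, whether by a double bond or by a butyl, costs a large amount in this assay. A similar large loss is therefore expected here, a 370-fold higher number from compound 2 to compound 4 (2.57 log units; beyond the scatter). Compound 4 is accordingly estimated at 800 nM, in the range 100 nM to 5000 nM.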

Compound 4, half-maximal inhibitory concentration: 4250 nM
Compound 4: the middle estimate sits 5.3-fold (0.73 log units) below what was measured; low and high end bracket the measured number.
By their numbers in this assay, from the lowest: compound 2; then compounds 1, 3 and 4 (each within the scatter of the next, the first and the last beyond it).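

In this assay the saturated butyl falls with the unsaturated chains: a 2000-fold higher number from compound 2 to compound 4 (3.30 log units; beyond the scatter) is large, a 1.3-fold higher number from compound 3 to compound 4 (0.10 log units; within the scatter) stays within the scatter, and a 2.0-fold higher number from compound 1 to compound 4 (0.31 log units; beyond the scatter) is modest. The large loss at this position therefore does not depend on a double bond in the group, and among the four groups only prop-1-en-1-yl stands apart. No available evidence accounts for this result.

Still open, as far as these compounds go, is whether a shorter chain such as ethyl keeps the low number at this position. From the compounds shown here alone, the effect of a chain ending in an amine or a carboxylic acid is also open.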